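A few compounds are considered here, and "the series" means these few. Any claim that something is new, unique, unknown or untested is made for them only; others in the source may bear on it.

Working notes on the series. All three measured compounds share one core and differ only in the substituent carried on the benzyl ring: compound 1 `O=c1cc(CNCc2cccc(Cl)c2)oc2ccc(O)c(O)c12` bears a chloro on an aromatic carbon, compound 2 `O=c1cc(CNCc2cccc(I)c2)oc2ccc(O)c(O)c12` an iodo and compound 3 `Cc1cccc(CNCc2cc(=O)c3c(O)c(O)ccc3o2)c1` a methyl. In an ADME assay on Huh-7 cells (Homo sapiens) for cytotoxicity (a higher number here means that more compound is tolerated, a lower number that less compound is tolerated), compound 1 gives > 100000 nM, which is a limit of the assay and not a number. Compound 2 likewise gives only a limit, > 100000 nM. Compound 3 stands at the same limit, > 100000 nM. Because the limit of > 100000 nM in this assay, at which 3 of the 3 values shown sit, holds for every value shown, the steps a step that the two limits leave unreadable from compound 1 to compound 2, a step that the two limits leave unreadable from compound 1 to compound 3 and a step that the two limits leave unreadable from compound 2 to compound 3 cannot be read in size; what they show is that chloro, iodo and methyl on that aromatic carbon all leave the compound tolerated up to the limit. Compound 4 `O=c1cc(CNCc2ccc(O)cc2)oc2ccc(O)c(O)c12` differs from compound 3 by 4-hydroxyphenyl in place of 3-methylphenyl on a saturated chain carbon bound to an amine nitrogen. For the measured compounds named here, no measured step covers an exchange of this kind, so nothing beyond the absence of any readable toxicity can be drawn on. A step that the limit leaves unreadable from compound 3 to compound 4 is therefore expected, that is, none beyond the scatter. For compound 4 a value of 150000 nM is estimated, with a range from 60000 nM to 400000 nM, and it is expected that this assay again reports only a limit.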

Compound 4, half-maximal cytotoxic concentration: 62700 nM
For compound 4 the middle estimate is 2.4-fold (0.38 log units) above the measured one; measured number inside the range.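

In this assay the exchange of the halogen- or methyl-bearing phenyl groups for 4-hydroxyphenyl on a saturated chain carbon bound to an amine nitrogen gives the first read-out of the series that is a number and not a limit, with an at least 1.5-fold lower number from compound 3 to compound 4 (0.20 log units; that floor lies within the scatter), an at least 1.5-fold lower number from compound 2 to compound 4 (0.20 log units; that floor lies within the scatter) and an at least 1.5-fold lower number from compound 1 to compound 4 (0.20 log units; that floor lies within the scatter). This position therefore does not always leave the read-out at the limit, which chloro, iodo and methyl alone could not show, yet each of the three floors lies within the scatter, so no real drop in tolerance is established. Only floors can be stated, and the full size of each step stays unreadable, because one side of every step is a limit: the limit of > 100000 nM in this assay, at which 3 of the 4 values shown sit.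

The change from compound 3 to compound 4 alters both the group and its place on the ring, so 3-hydroxyphenyl and 4-methylphenyl on the same carbon would be needed to separate the two. From the compounds shown here alone, how a 4-methoxyphenyl group, or a phenyl ring carrying an amine or a carboxylic acid, would read in this assay stays open.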